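The source may report more compounds than this note shows. Statements on the series, on what has been measured and on what is new or still open speak of the compounds shown alone.

In a functional assay on A-427 cells (Homo sapiens) for cytotoxicity, read by colorimetric assay and MTT assay (a higher number here means a weaker inhibitor, a lower number a stronger inhibitor), compound 1 (`COc1ccc2cc(-c3ccccc3)c(O)nc2c1`) gives 10000 nM. In this assay compound 2 (`CCOC(=O)Cn1c(=O)c(-c2ccc(OC)cc2)cc2c(OC)cc(OC)cc21`) gives 10000 nM, level with compound 1 within the scatter. Compound 3 (`COc1ccc(-c2cc3c(OC)cc(OC)cc3n(CC#N)c2=O)cc1`) has yet to be measured. It carries cyano in place of ethoxycarbonyl on a saturated chain carbon bound to an aromatic nitrogen. Among the measured compounds shown here, no measured pair shows what this change does in this assay, so no shift beyond the scatter is expected. The expected step is no change at the digits printed from compound 2 to compound 3 (within the scatter). The estimate for compound 3 is 10000 nM, with an expected range from 3500 nM to 25000 nM.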

Compound 3, half-maximal inhibitory concentration: 10000 nM
The estimate for compound 3 equals the measured number at the digits printed; measured number inside the range.
By their numbers in this assay, from the lowest: compounds 1, 2 and 3 (each within the scatter of the next).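

Cyano in place of ethoxycarbonyl on a saturated chain carbon bound to an aromatic nitrogen gives the first reading at this position in this assay: no change at the digits printed from compound 2 to compound 3 (within the scatter). The entering group has 2 heavy atoms against 5 in the leaving group, and this difference in size does not separate the two compounds here. No supporting data bear on this result. Going by these compounds, whether a carboxylic acid, an amine or a longer chain at this position would move the value remains open.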